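The source may hold more compounds than are shown below. What is called first, only, known or untested is meant among the compounds shown, and "the series" means these compounds.

Among the compounds with values here, compound 2, `COc1cc(Oc2cccc(Nc3ccccc3)c2)cc(OC)c1CNCc1ccc(F)cc1`, is one of two compounds measured in a functional assay on DLD-1 cells (Homo sapiens) for inhibition, read by MTT assay, with a stated time of 72 h; on this read-out lower numbers stand for stronger inhibition and higher numbers for weaker inhibition. In this assay compound 2 gives 2650 nM. The other measured compound, compound 1, `COc1ccc(CCCNCc2c(OC)cc(Oc3ccc(Nc4ccccc4)cc3)cc2OC)cc1`, gives 4650 nM in this assay. The two structures differ in more than one place, so the pair is reported side by side only; the gap between them lies within the usual scatter of such measurements, and neither compound can be called the more potent of the two.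

Compound 3, `COc1cc(Oc2cccc(Nc3ccccc3)c2)cc(OC)c1CNCc1ccc(C)cc1`, has not yet been measured in this assay. Set against compound 2, it differs in a single change: methyl in place of fluoro on an aromatic carbon. Within the data shown here, no step of this kind between two measured compounds is available, so the expectation rests on the nature of the change alone, one small substituent replaced by another of the same size, with nothing else added or removed. Compound 3 is therefore expected to give about 3000 nM in this assay, with a range from 1200 nM to 7500 nM. The expected step of a 1.1-fold higher number from compound 2 to compound 3 (0.05 log units; within the scatter) is small, with no clear direction, and most likely within the scatter.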

Compound 3, half-maximal inhibitory concentration: 6080 nM
Estimate against measurement, compound 3: 2.0-fold (0.31 log units) below, within the range that was stated.
By their numbers in this assay, from the lowest: compounds 2, 1 and 3 (each within the scatter of the next, the first and the last beyond it).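

In this assay, within the data shown here, the exchange of fluoro for methyl on an aromatic carbon para to a large group gives a 2.3-fold higher number from compound 2 to compound 3 (0.36 log units; beyond the scatter) and so offers the first change in a single place that can be read on its own. This position is therefore not indifferent to which of the two groups it carries: the count of heavy atoms stays the same, no hydrogen-bond donor or acceptor enters or leaves, and still the number moves modestly towards weaker inhibition. Nothing among the data shown accounts for this step.

Among these compounds, with only this single pair, it remains open whether fluoro raises the inhibition, methyl lowers it, or both contribute, and a comparison with hydrogen, chloro, methoxy or trifluoromethyl at the same position would be needed to separate these readings. Going by these compounds, it also remains open whether the same exchange would produce a step of similar size and direction on the core of compound 1, which differs from compound 2 in more than one place.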